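Piperidine to morpholine on the amide carbonyl

The compounds below may be only part of what the source reports. "The series", "measured", "known", "first", "only" and "open" are said of these compounds alone.

Compound 1 `COC(=O)C1=C(C)NC(C)=C(C(=O)OC)C1c1cccc(OCC(=O)N2CCN(C)CC2)c1` carries a 4-methylpiperazin-1-yl group on a carbonyl carbon. In an assay on cells for inhibition of Voltage-gated L-type calcium channel (Rattus norvegicus), read by fluorescence and calcium flux, with stated times of 30 min and 2 min (on this read-out higher numbers stand for weaker inhibition and lower numbers for stronger inhibition), compound 1 gives 10000 nM. Compound 2 `COC(=O)C1=C(C)NC(C)=C(C(=O)OC)C1c1cccc(OCC(=O)N2CCCCC2)c1` bears piperidin-1-yl on that carbonyl carbon, and in this assay compound 2 gives 10000 nM. For the measured compounds named here, the one step measured so far, no change at the digits printed from compound 1 to compound 2 (within the scatter), shows that exchanging one six-membered ring for another on the carbonyl carbon left the read-out level. Compound 2 therefore stands level with compound 1 on the numbers at hand. Compound 3 `COC(=O)C1=C(C)NC(C)=C(C(=O)OC)C1c1cccc(OCC(=O)N2CCOCC2)c1` differs from compound 2 by morpholin-4-yl in place of piperidin-1-yl on a carbonyl carbon. Going by the values given here, the only step that bears on this change, no change at the digits printed from compound 1 to compound 2 (within the scatter), was flat, so no movement beyond the scatter is expected in this assay in either direction. The expected step is no change at the digits printed from compound 2 to compound 3 (within the scatter). Compound 3 is accordingly estimated at 10000 nM, with a range from 3000 nM to 30000 nM.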

Compound 3, half-maximal inhibitory concentration: 9900 nM
The estimate for compound 3 lay 1.0-fold (0.00 log units) above the measured number, and the stated range covers the measured number.
By their numbers in this assay, from the lowest: compounds 3, 1 and 2 (each within the scatter of the next).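

In this assay, morpholin-4-yl on the carbonyl carbon gives a 1.0-fold lower number from compound 2 to compound 3 (0.00 log units; within the scatter), and against 4-methylpiperazin-1-yl it gives a 1.0-fold lower number from compound 1 to compound 3 (0.00 log units; within the scatter). Exchanging piperidin-1-yl for morpholin-4-yl adds a second hetero atom and a hydrogen-bond acceptor to the ring, yet the read-out stays level, so all three six-membered rings at this place now lie within the scatter of one another. No measurement at hand accounts for this flat result.

The compounds shown leave open whether any group on this carbonyl carbon moves the number, for instance an open-chain diethylamino group or a hydroxyl that would make the carboxylic acid. Also open, from the compounds shown here alone, is how a longer chain carrying the same morpholin-4-yl amide would read in this assay.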